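The compounds below may be only part of what the source reports. "The series", "measured", "known", "first", "only" and "open" are said of these compounds alone.

Compound 1 `Cc1nc2c(s1)C(=O)C=C(Nc1ccc(C(F)(F)F)cc1)C2=O` — > 100 ug/mL
Compound 2 `O=C1C=C(Nc2cccc(F)c2)C(=O)c2scnc21` — > 100 ug/mL

In a functional assay on HepG2 cells (Homo sapiens) for cytotoxicity, read by MTT assay (a higher number here means a weaker inhibitor, a lower number a stronger inhibitor), compound 1 gives > 100 ug/mL, which is a limit of the assay and not a number. In this assay compound 2 likewise gives > 100 ug/mL, again a limit rather than a number. Compound 1 thus stands at the limit of > 100 ug/mL in this assay, at which 2 of the 2 values shown sit, so no numerical position is known for it, and the two compounds share the same limit without any step between them.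

Compound 3 `CCCCCCc1ccc(NC2=CC(=O)c3sc(C)nc3C2=O)cc1` differs from compound 1 by hexyl in place of trifluoromethyl on an aromatic carbon. No measured step describes such a change, so the expectation rests on the limit shown for compound 1 alone. Compound 3 is expected to show a step of an at least 1.1-fold lower number from compound 1 to compound 3 (0.04 log units; that floor lies within the scatter), that is, nothing beyond the scatter. For compound 3 the estimated value in this assay is 90 ug/mL, within a range from 30 ug/mL to 200 ug/mL, with a real chance that only a limit is reported.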

Compound 3, half-maximal inhibitory concentration: 22 ug/mL
Compound 3: middle estimate off by 4.1-fold (0.61 log units), on the high side; measured number below the stated range.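

In this assay, hexyl in place of trifluoromethyl on an aromatic carbon, para to a large group, brings an at least 4.5-fold lower number from compound 1 to compound 3 (0.65 log units; beyond the scatter). The earlier pair showed only a shared limit, whereas this step shows that the group at this position can carry a compound from a limit to a measured number. Compound 3 is the only compound shown that gives a number, so the size of this step has a floor but no upper end: the limit of > 100 ug/mL in this assay, at which 2 of the 3 values shown sit.

From the compounds shown here alone, whether butyl, a longer chain, an amine or a carboxylic acid in the same place would give a lower or a higher number stays open. Going by these compounds, it also stays open whether the step follows from the arrival of hexyl or from the departure of trifluoromethyl, as the two occur together in this single change.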